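A ring swap in a series known only by a limit

A few compounds are considered here, and "the series" means these few. Any claim that something is new, unique, unknown or untested is made for them only; others in the source may bear on it.

Compound 1 `NS(=O)(=O)c1cccc(-c2ccc3nccc(-c4ccncc4)c3n2)c1` gives < 5000 nM as a limit
Compound 2 `NS(=O)(=O)c1cccc(-c2ccc3nccc(-c4cccnc4)c3n2)c1` gives < 5000 nM as a limit
Compound 3 `NS(=O)(=O)c1cccc(-c2ccc3nccc(-c4cn[nH]c4)c3n2)c1` gives < 5000 nM as a limit

In a physicochemical assay for solubility, read by HPLC, using the shake flask method, measured as kinetic solubility, with a stated time of 20 h, at pH 6.5, tested at 200 uM (a lower number here means a less soluble compound, a higher number a more soluble compound), compound 3 has no exact number, only the limit < 5000 nM on record. Going by the values given here, the other two compounds are limits as well, and the series so far offers nothing sharper than the limit of < 5000 nM in this assay, at which 3 of the 3 values shown sit, to work from.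

The next compound is compound 4 `NS(=O)(=O)c1cccc(-c2ccc3nccc(-c4ccncc4F)c3n2)c1` in which 3-fluoropyridin-4-yl stands in place of 1H-pyrazol-4-yl on an aromatic carbon of the shared core. Counted atom by atom, the change is 3-fluoropyridin-4-yl in place of 1H-pyrazol-4-yl on an aromatic carbon and it sits opposite the ring nitrogen.

Three measured steps also swap one ring for another on an aromatic carbon. They are a step that the two limits leave unreadable from compound 1 to compound 2 and a step that the two limits leave unreadable from compound 1 to compound 3 and finally a step that the two limits leave unreadable from compound 2 to compound 3 and none of them has a size that can be read. They therefore suggest no direction, and no step beyond the usual scatter is expected in this assay for this swap.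

The expectation leans on compound 3 at < 5000 nM as a limit and on nothing sharper. The expected move is a step that the limit leaves unreadable from compound 3 to compound 4 as an estimate with no firm direction. Compound 4 is estimated at 2500 nM within an expected range from 800 nM to 7000 nM and will most likely be reported as a limit again.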

Compound 4, solubility: < 5000 nM
Compound 4: only a limit was reported (the forecaster's own chance of this, stated with the estimate: 85%); the middle value is on the limit's open side.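

In this assay compound 4 gives < 5000 nM, which is a limit and not a number. Its steps from compound 1, compound 2 and compound 3 therefore cannot be read, and all four compounds rest on the same reading: the limit of < 5000 nM in this assay, at which 4 of the 4 values shown sit.

From the compounds shown here alone, what stays open is how the exact solubilities of these four compounds compare, and whether any of these ring swaps shifts them at all.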